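Changing the amide-side aryl group in a cytotoxicity series

The source may report more compounds than this note shows. Statements on the series, on what has been measured and on what is new or still open speak of the compounds shown alone.

Compound 1 `Cc1ccc(NC(=O)c2cccc(/C=C3\CC(=O)N(c4ccccc4)C3=O)c2)cc1`: > 100000 nM
Compound 2 `O=C(Nc1ccc(OC(F)F)cc1)c1cccc(/C=C2\CC(=O)N(c3ccccc3)C2=O)c1`: > 100000 nM
Compound 3 `CCc1cccc(NC(=O)c2cccc(/C=C3\CC(=O)N(c4ccccc4)C3=O)c2)c1`: 88600 nM

Among the compounds with values here, in an ADME assay on SW480 cells (Homo sapiens) for cytotoxicity, read by MTT assay, with a stated time of 72 h (on this read-out higher numbers stand for weaker inhibition and lower numbers for stronger inhibition), compound 3 gives 88600 nM, the only outright number among the three. Compound 1 gives > 100000 nM, a limit of the assay rather than a number. Compound 2 also reaches only the limit > 100000 nM. Compound 4 `COc1ccc(NC(=O)c2cccc(/C=C3\CC(=O)N(c4ccccc4)C3=O)c2)c(C)c1` differs from compound 3 by 4-methoxy-2-methylphenyl in place of 3-ethylphenyl on an amide-type nitrogen. Within the data shown here, no measured step makes this exact exchange; the nearest are an at least 1.1-fold lower number from compound 1 to compound 3 (0.05 log units; that floor lies within the scatter) and an at least 1.1-fold lower number from compound 2 to compound 3 (0.05 log units; that floor lies within the scatter), both small and both starting from the limit of > 100000 nM in this assay, at which 2 of the 3 values shown sit. With each change of the amide-side aryl group so far leaving the result at or near that limit, the step of a 1.1-fold higher number from compound 3 to compound 4 (0.05 log units; within the scatter) is expected to stay within the scatter. Compound 4 is therefore estimated at 100000 nM, between 40000 nM and 250000 nM, and may well register only as a limit again.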

Compound 4, half-maximal inhibitory concentration: > 100000 nM
Compound 4: a limit, no number (the forecaster's own chance of this, stated with the estimate: 55%); the middle value sits exactly at the limit.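

Exchanging 3-ethylphenyl for 4-methoxy-2-methylphenyl on the amide-type nitrogen gives an at least 1.1-fold higher number from compound 3 to compound 4 (0.05 log units; that floor lies within the scatter), so this oxygen-bearing group opens no readable gap from compound 3 in this assay. The steps from compound 1 and from compound 2 to compound 4 cannot be read, as both ends of each are limits. Compound 4 therefore adds one more amide-side aryl group to those at the limit: the limit of > 100000 nM in this assay, at which 3 of the 4 values shown sit.

Still open, on these data alone, is whether an amine or a carboxylic acid on this aryl group would give a clearly lower number. As far as these compounds go, a longer alkyl chain in place of the aryl group remains equally open.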